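Swapping bromo for methyl on the aryl of compound 3

This account rests on a few compounds, and the source may have more. Where it says the series, first, only, none or still open, it means among the compounds named here.

Measured so far in a functional assay on HCT-116 cells (Homo sapiens) for inhibition, read by sulforhodamine B assay, with a stated time of 72 h; a lower number here means a stronger inhibitor, a higher number a weaker inhibitor:
- compound 1, `CC(c1ccc(-c2ccccc2)c(F)c1)c1nnc2n1N=C(c1ccc(Cl)cc1Cl)CS2`: 6900 nM
- compound 2, `CC(c1ccc(-c2ccccc2)c(F)c1)c1nnc2n1N=C(c1ccccc1)CS2`: 9700 nM
- compound 3, `CC(c1ccc(-c2ccccc2)c(F)c1)c1nnc2n1N=C(c1ccc(Br)cc1)CS2`: 7100 nM

Compound 3 stands between the others in this assay, and all three values lie within the scatter of one another: a 1.0-fold higher number from compound 1 to compound 3 (0.01 log units; within the scatter) and a 1.4-fold lower number from compound 2 to compound 3 (0.14 log units; within the scatter). The new compound 4, `Cc1ccc(C2=Nn3c(nnc3C(C)c3ccc(-c4ccccc4)c(F)c3)SC2)cc1`, differs from compound 3 by methyl in place of bromo on an aromatic carbon. Among the compounds with values here, no measured step shows exactly this swap. The nearest comparison is a 1.4-fold lower number from compound 2 to compound 3 (0.14 log units; within the scatter), and the change of the whole aryl group in a 1.4-fold higher number from compound 1 to compound 2 (0.15 log units; within the scatter) also stayed within the scatter. Every change on this ring so far has left the number about where it was, so compound 4 is expected to move by a 1.1-fold higher number from compound 3 to compound 4 (0.02 log units; within the scatter) at most, meaning no step beyond the scatter. The estimate for compound 4 is 7500 nM, expected between 3500 nM and 16000 nM.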

Compound 4, half-maximal inhibitory concentration: 4800 nM
Compound 4: the middle estimate sits 1.6-fold (0.19 log units) above what was measured; the measured number falls inside the stated range.
By their numbers in this assay, from the lowest: compounds 4, 1, 3 and 2 (each within the scatter of the next, the first and the last beyond it).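

Within the data shown here, the 4-methylphenyl group gives a 2.0-fold lower number from compound 2 to compound 4 (0.31 log units; beyond the scatter) in this assay and so is the first change on this ring to leave the scatter, though only modestly. It stands apart from neither halogen-bearing compound: a 1.5-fold lower number from compound 3 to compound 4 (0.17 log units; within the scatter) and a 1.4-fold lower number from compound 1 to compound 4 (0.16 log units; within the scatter) both stay within the scatter. Nothing measured here explains why methyl in place of hydrogen gives this step.

Still open, on these data alone, is whether another group at this place on the ring, such as an amine, a carboxylic acid or a longer chain like propyl, would carry the number further beyond the scatter.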